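The compounds below may be only part of what the source reports. "The series", "measured", "known", "first", "only" and "open" are said of these compounds alone.

Compound 2 `Cc1ccc(C#Cc2ccc3c(n2)CCN(C2CCCCC2)C3=O)cc1` gives 27200 nM in an assay on HEK293 cells for displacement of a labelled ligand from metabotropic glutamate receptor 5 (Homo sapiens), with a stated time of 2 h (a lower number here means a stronger inhibitor, a higher number a weaker inhibitor), the highest of the two numbers recorded so far. Among the measured compounds shown here, its nearest neighbour is compound 1 `Cc1cccc(C#Cc2ccc3c(n2)CCN(C2CCCCC2)C3=O)c1`, which in this assay gives 3210 nM; the only measured step is an 8.5-fold higher number from compound 1 to compound 2 (0.93 log units; beyond the scatter), a change of 4-methylphenyl for 3-methylphenyl on a triple-bonded carbon. Compound 3 `O=C1c2ccc(C#Cc3cccc(Cl)c3)nc2CCN1C1CCCCC1` is reached from compound 2 by 3-chlorophenyl in place of 4-methylphenyl on a triple-bonded carbon. That single step is the only one that bears on the change: a 3-methylphenyl gave a markedly lower number than a 4-methylphenyl, and compound 3 again carries a 3-substituted phenyl, now with chlorine rather than methyl. A lower number is therefore expected in this assay, of a size comparable to the measured step, so the expected step is a 9.1-fold lower number from compound 2 to compound 3 (0.96 log units; beyond the scatter). For compound 3 the estimate is 3000 nM, with a range from 800 nM to 10000 nM.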

Compound 3, inhibition constant: 12000 nM
The estimate for compound 3 lay 4.0-fold (0.60 log units) below the measured number; measured number outside the range, above it.
By their numbers in this assay, from the lowest: compound 1; then compound 3; then compound 2.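

In this assay the 3-chlorophenyl of compound 3 gives a 2.3-fold lower number from compound 2 to compound 3 (0.36 log units; beyond the scatter), so a 3-substituted phenyl again does better than the 4-methylphenyl, though by less than the methyl pair suggested. The new result also shows that the substituent itself matters and not only where it stands: chloro in place of methyl on an aromatic carbon gives a 3.7-fold higher number from compound 1 to compound 3 (0.57 log units; beyond the scatter), leaving compound 1 with the lowest number of the three. Nothing at hand explains either difference.

The compounds shown leave open how a 4-chlorophenyl would compare, which would separate the effect of chlorine from that of its place on the ring. They also leave open whether a plain phenyl or a 3-methoxyphenyl would fall below compound 1 or above it.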